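From fluoro to isopropyl on the shared core

The compounds below may be only part of what the source reports. "The series", "measured", "known", "first", "only" and "open" are said of these compounds alone.

Compound 2 `COc1ccc(-c2[nH]c3ccc(F)cc3c2C=C(C#N)C#N)cc1` gives 310 nM in a functional assay on MCF7 cells (Homo sapiens) for antiproliferative activity, with a stated time of 5 days (a lower number here means a stronger inhibitor, a higher number a weaker inhibitor), and its number lies within the scatter of the two other measured compounds. Compound 1 `COc1ccc(-c2[nH]c3ccc(OC)cc3c2C=C(C#N)C#N)cc1` gives 340 nM and compound 3 `COc1ccc(-c2[nH]c3cc(Cl)c(C)cc3c2C=C(C#N)C#N)cc1` gives 200 nM in the same test. The change to compound 4 `COc1ccc(-c2[nH]c3ccc(C(C)C)cc3c2C=C(C#N)C#N)cc1` is isopropyl in place of fluoro on an aromatic carbon with isopropyl in place of fluoro on an aromatic carbon. Within the data shown here, the only measured step at this place is a 1.1-fold lower number from compound 1 to compound 2 (0.04 log units; within the scatter) and it stays within the scatter. Among the measured compounds shown here, no measured compound carries isopropyl there, so no step beyond the scatter is expected in this assay and no direction can be argued firmly. The expected step is a 1.1-fold higher number from compound 2 to compound 4 (0.05 log units; within the scatter) and this is only an estimate. Compound 4 is estimated at 350 nM with an expected range of 130 nM to 900 nM for its value.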

Compound 4, half-maximal inhibitory concentration: 310 nM
Compound 4: middle estimate off by 1.1-fold (0.05 log units), on the high side, and the stated range covers the measured number.
By their numbers in this assay, from the lowest: compounds 3, 2, 4 and 1 (each within the scatter of the next).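

In this assay isopropyl gives no change at the digits printed from compound 2 to compound 4 (within the scatter) and a 1.1-fold lower number from compound 1 to compound 4 (0.04 log units; within the scatter) at this place, so the position now holds three different groups with all their numbers within the scatter. Earlier, only fluoro and methoxy could be compared here, whereas isopropyl adds a branched group of 3 carbon atoms to that comparison. No supporting evidence bears on why these numbers stay so close. As far as these compounds go, whether an amine or a carboxylic acid at this position would leave the number within the scatter stays open. So does whether a longer chain would.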